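Amide-side variation on the shared core of compound 3

This account rests on a few compounds, and the source may have more. Where it says the series, first, only, none or still open, it means among the compounds named here.

Three compounds share the core of compound 1 `COCCNC(=O)Cn1sc2ccccc2c1=O`. In an assay on isolated protein for inhibition of histone acetyltransferase p300 (Homo sapiens), read by fluorescence, with a stated time of 10 min, tested at 50 uM (a higher number here means more inhibition at the concentration tested (going by the name of the read-out), a lower number less inhibition), compound 1 gives 45.1%, compound 2 `Cc1ccc(-c2csc(-n3sc4ccccc4c3=O)n2)cc1` gives 45.8%, and compound 3 `O=C(Cn1sc2ccccc2c1=O)NCc1ccccn1` gives 24%, the lowest of the three; compound 2 sits furthest above it, compound 1 nearest. Within the data shown here, the one single-point step, a number 21.1 percentage points lower from compound 1 to compound 3 (beyond the scatter), shows that changing the group on the amide-type nitrogen moves this assay beyond the scatter. Compound 4 `O=C(Cn1sc2ccccc2c1=O)Nc1nccs1` carries 1,3-thiazol-2-yl in place of (pyridin-2-yl)methyl on an amide-type nitrogen. Among the measured compounds shown here, no measured step covers this exchange; it bears only on the same amide-type nitrogen as the step from compound 1 to compound 3. Compound 4 is therefore expected near the middle of the series, a step of a number 11 percentage points higher from compound 3 to compound 4 (beyond the scatter) upward, estimated at 35% within 15% to 55%.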

Compound 4, a percentage reported as inhibition, at one concentration (the size of the read-out at that concentration, not a potency): 57.4%
Beside the measured number, compound 4's estimate is 22.4 percentage points below it, and the stated range ends below it.
By their numbers in this assay, from the lowest: compound 3; then compounds 1 and 2 (each within the scatter of the next); then compound 4.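

Among these compounds, on the amide-type nitrogen, 1,3-thiazol-2-yl in place of (pyridin-2-yl)methyl gives a number 33.4 percentage points higher from compound 3 to compound 4 (beyond the scatter) in this assay and is the largest step at this position so far. In place of 2-methoxyethyl, the same group gives a number 12.3 percentage points higher from compound 1 to compound 4 (beyond the scatter) and so shows that changes at this nitrogen can raise the number as well as lower it.

The first step changes the ring and removes the methyl link together, so a phenyl or pyridin-2-yl ring bound directly to this nitrogen would be needed to separate the two. Nothing available explains either step.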